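This account rests on a few compounds, and the source may have more. Where it says the series, first, only, none or still open, it means among the compounds named here.

In a functional assay on HepG2 cells (Homo sapiens) for antiproliferative activity, read by MTT assay, with a stated time of 48 h (a higher number here means a weaker inhibitor, a lower number a stronger inhibitor), compound 3 `COc1ccc(-c2c(Nc3ccc(NC(C)=O)cc3)c3ccc(O)cc3oc2=O)cc1` gives > 100000 nM, which is a limit of the assay and not a number. That single ceiling value is the whole of the evidence at the top of the range: the limit of > 100000 nM in this assay, at which 1 of the 3 values shown sits. Moving to compound 4 `COc1ccc(-c2c(Nc3cccc(C(F)(F)F)c3)c3ccc(O)cc3oc2=O)cc1`, the change is 3-(trifluoromethyl)phenyl in place of 4-acetamidophenyl on a nitrogen on an aromatic ring. Among the measured compounds shown here, one measured step bears on this: an at least 1.5-fold higher number from compound 2 to compound 3 (0.18 log units; that floor lies within the scatter), with acetamido in place of fluoro on an aromatic carbon. Compound 2 `COc1ccc(-c2c(Nc3ccc(F)cc3)c3ccc(O)cc3oc2=O)cc1` gives 65600 nM in this assay. Compound 1 `COc1ccc(-c2c(Nc3cccc(C(F)(F)F)c3)c3ccccc3oc2=O)cc1` carries the same 3-(trifluoromethyl)phenyl group without the hydroxyl on the core and gives 66400 nM. As far as these compounds go, with compound 3 only a limit, the true size of the step stays open. A move to a lower number in this assay is expected, reaching the level of compound 1 at 66400 nM. The expected step is an at least 1.6-fold lower number from compound 3 to compound 4 (0.22 log units; that floor lies within the scatter). For compound 4 the estimated value is 60000 nM, with an expected range of 30000 nM to 100000 nM.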

Compound 4, half-maximal inhibitory concentration: 53600 nM
Estimate against measurement, compound 4: 1.1-fold (0.05 log units) above, and the stated range covers the measured number.
By their numbers in this assay, from the lowest: compounds 4, 2 and 1 (each within the scatter of the next). At a limit, above all of these: compound 3.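

In this assay, among the compounds shown here, hydroxy in place of hydrogen on an aromatic carbon gives a 1.2-fold lower number from compound 1 to compound 4 (0.09 log units; within the scatter), the first reading of that change, and it rests on this one pair. As far as these compounds go, on the nitrogen on an aromatic ring, 3-(trifluoromethyl)phenyl in place of 4-fluorophenyl gives a 1.2-fold lower number from compound 2 to compound 4 (0.09 log units; within the scatter), and in place of 4-acetamidophenyl it gives an at least 1.8-fold lower number from compound 3 to compound 4 (0.27 log units; that floor lies within the scatter), whose true size stays open. Compound 3 is a limit and not a number: the limit of > 100000 nM in this assay, at which 1 of the 4 values shown sits.

From the compounds shown here alone, whether the hydroxy change reads the same with another group on the nitrogen remains open. Also open, going by these compounds, is whether a carboxylic acid, a morpholine or a longer aminoalkyl chain in place of the 3-(trifluoromethyl)phenyl would move the number beyond the scatter from compound 4.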